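The source may hold more compounds than are shown below. What is called first, only, known or untested is meant among the compounds shown, and "the series" means these compounds.

Compound 1, `Cc1cccc2c1cnn2-c1ccc(NC(=O)Nc2ccc(Cl)c(C(F)(F)F)c2)cc1`, is one of three closely related ureas tested in a functional assay on SGC-7901 cells (Homo sapiens) for cytotoxicity, read by MTT assay, with a stated time of 72 h; on this read-out higher numbers stand for weaker inhibition and lower numbers for stronger inhibition. In this assay compound 1 gives 14200 nM, the second highest of the three numbers. Compound 2, `CNc1cccc2c1cnn2-c1ccc(NC(=O)Nc2ccc(Cl)c(C(F)(F)F)c2)cc1`, gives 6900 nM in this assay, and compound 3, `COc1cccc2c1cnn2-c1ccc(NC(=O)Nc2ccc(Cl)c(C(F)(F)F)c2)cc1`, gives 29800 nM. The steps among them are modest: a 2.1-fold lower number from compound 1 to compound 2 (0.31 log units; beyond the scatter), a 2.1-fold higher number from compound 1 to compound 3 (0.32 log units; beyond the scatter) and a 4.3-fold higher number from compound 2 to compound 3 (0.64 log units; beyond the scatter). Each of these steps alters only the small group on the six-membered ring of the shared core, and the rest of the molecule stays the same.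

Compound 4, `O=C(Nc1ccc(-n2ncc3cccnc32)cc1)Nc1ccc(Cl)c(C(F)(F)F)c1`, is a different kind of change. Relative to compound 1 it carries a group of 9 heavy atoms (6 carbon, 3 nitrogen; one five-membered aromatic ring with 2 hetero atoms, one six-membered aromatic ring with 1 hetero atom) in place of a group of 10 heavy atoms (8 carbon, 2 nitrogen; one five-membered aromatic ring with 2 hetero atoms, one six-membered aromatic ring of carbon only), on an aromatic carbon, placed on an aromatic carbon of a six-membered aromatic ring of carbon only, para to a large group. Among the measured compounds shown here, no measured step replaces the whole fused ring system in this way, so the three steps bear on it only indirectly: they show that alterations at this end of the molecule move the number in both directions by modest amounts, and by nothing larger. A modest step from compound 1 to compound 4 in this assay, of uncertain direction, is therefore expected, which is what a 1.1-fold higher number from compound 1 to compound 4 (0.02 log units; within the scatter) means. On that basis compound 4 is estimated at 15000 nM in this assay, with a range from 5000 nM to 45000 nM.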

Compound 4, half-maximal inhibitory concentration: > 32000 nM
Compound 4: a limit, no number; the forecaster's own chance of this, stated with the estimate: 10%; middle value at least 2.1-fold (0.32 log units) away from the limit.
By their numbers in this assay, from the lowest: compound 2; then compound 1; then compound 3. At a limit, above all of these: compound 4.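

In this assay compound 4 yields only a limit, not a number: the limit of > 32000 nM in this assay, at which 1 of the 4 values shown sits. The new step is an at least 2.2-fold higher number from compound 1 to compound 4 (0.35 log units; beyond the scatter), and it runs towards weaker inhibition, the same direction as the methoxy step and the opposite of the methylamino step. Among the compounds shown here, it is also the first change here that alters the six-membered ring of the fused group itself, since a ring nitrogen enters and the methyl of the 4-methyl-1H-indazol-1-yl group is gone, and the limit leaves its full size unread.

Because both alterations arrive together in this one step, the compounds shown cannot say how much of it belongs to the ring nitrogen and how much to the missing methyl, a question that the unsubstituted 1H-indazol-1-yl group, or the same nitrogen-containing ring carrying a methyl, would address. They also leave open how a primary amine, a hydroxyl, a carboxylic acid or a longer chain such as ethylamino would behave in place of the methyl on the shared core.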